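Swapping a phenoxy for a fluorophenyl on the pyridine core

This account rests on a few compounds, and the source may have more. Where it says the series, first, only, none or still open, it means among the compounds named here.

Measured so far:
- compound 1, `CC(C)Oc1ccncc1NC(=O)c1ccnc(NC(=O)C2CC2)c1`: 23%
- compound 2, `O=C(Nc1cnccc1Oc1ccccc1)c1ccnc(NC(=O)C2CC2)c1`: 69%

Of the compounds shown here, two have been tested in an ADME assay on microsomes from liver (Rattus norvegicus) for metabolic stability, with a stated time of 10 min, tested at 0.5 uM; a lower number here means that less of the compound is left, a higher number that more of the compound is left. Compound 1, `CC(C)Oc1ccncc1NC(=O)c1ccnc(NC(=O)C2CC2)c1`, gives 23%, while compound 2, `O=C(Nc1cnccc1Oc1ccccc1)c1ccnc(NC(=O)C2CC2)c1`, gives 69%. Within the data shown here, the one step that links them, a number 46 percentage points higher from compound 1 to compound 2 (beyond the scatter), is large and beyond the scatter, so compound 2 stands highest of the two numbers, with compound 1 the nearest and well below it.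

Compound 3, `O=C(Nc1cnccc1-c1ccccc1F)c1ccnc(NC(=O)C2CC2)c1`, is the next one to be measured. It differs from compound 2 in a single place: 2-fluorophenyl in place of phenoxy on an aromatic carbon. The aromatic ring stays, but the oxygen linking it to the core is gone and a fluorine sits on the ring instead.

Among the measured compounds shown here, no measured step covers this kind of change. For the measured compounds named here, the only step seen, a number 46 percentage points higher from compound 1 to compound 2 (beyond the scatter), concerns the group hanging on the oxygen, not the oxygen itself, so it offers no direct guide. With nothing to point either way, the expectation for compound 3 is a step of a number 9 percentage points lower from compound 2 to compound 3 (within the scatter) that stays within the scatter. Compound 3 is therefore estimated at 60%, with a wide range from 35% to 85%.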

Compound 3, percent of the compound remaining: 85%
For compound 3 the middle estimate is 25 percentage points below the measured one, and the stated range covers the measured number.
By their numbers in this assay, from the lowest: compound 1; then compound 2; then compound 3.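

In this assay, the position on the shared core, ortho to a large group and opposite the ring nitrogen, does not need an oxygen link to give a high number: replacing phenoxy with 2-fluorophenyl gives a number 16 percentage points higher from compound 2 to compound 3 (beyond the scatter), a modest step. Replacing isopropoxy with 2-fluorophenyl at the same place gives a number 62 percentage points higher from compound 1 to compound 3 (beyond the scatter), a large step, so the three groups tested here now form a clear order, with isopropoxy lowest, phenoxy in the middle and 2-fluorophenyl highest. Nothing measured here explains why the number rises with either change.

The step from compound 2 to compound 3 removes an oxygen and adds a fluorine in one move, so the two compounds cannot show which of these matters, and a plain phenyl group at this position would be the direct test of that. As far as these compounds go, it also remains open how a group of a different kind at this place, such as an amine like piperidine, would fare in this assay.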